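Swapping the benzyl group of compound 3 for a trimethylphenyl ring

The source may report more compounds than this note shows. Statements on the series, on what has been measured and on what is new or still open speak of the compounds shown alone.

Of the compounds shown here, three built on one shared core have been tested in an ADME assay on L02 cells (Homo sapiens) for inhibition, read by CCK-8 assay, with a stated time of 48 h; a higher number here means a weaker inhibitor of growth, a lower number a stronger inhibitor of growth. Compound 1 `Cc1ccccc1Nc1nc(NCc2ccco2)ncc1Cl` gives only a limit of the assay, > 100000 nM. Compound 2 `CCN1CCN(c2ccc(Nc3ncc(Cl)c(Nc4ccccc4C)n3)nc2)CC1` likewise gives only a limit, > 100000 nM. For the measured compounds named here, compound 3 `COc1ccc(CNc2nc(Nc3ccc(N4CCN(C)CC4)cn3)ncc2Cl)cc1` is the one compound that gives a number, 12900 nM, so it stands alone as the only measured point, with nothing to rank it against. That two of three results sit at the limit is itself worth noting (the limit of > 100000 nM in this assay, at which 2 of the 3 values shown sit).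

Compound 4 `Cc1cc(C)c(Nc2nc(Nc3ccc(N4CCN(C)CC4)cn3)ncc2Cl)c(C)c1` is not yet measured. It differs from compound 3 in one place: 2,4,6-trimethylphenyl in place of 4-methoxybenzyl on a nitrogen on an aromatic ring. Going by the values given here, no measured pair in this set differs in just this way, so the step cannot be read off from a neighbour. The expected step in this assay from compound 3 to compound 4 is towards a higher number, meaning weaker inhibition of growth, because compound 2 gives > 100000 nM, a limit of the assay, and compound 2 likewise carries a substituted phenyl on that nitrogen. Compound 4 is therefore expected to give about 50000 nM, somewhere between 10000 nM and 150000 nM, as a 3.9-fold higher number from compound 3 to compound 4 (0.59 log units; beyond the scatter).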

Compound 4, concentration for 50% growth inhibition: 20500 nM
The estimate for compound 4 lay 2.4-fold (0.39 log units) above the measured number, and the stated range covers the measured number.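

In this assay, the step is a 1.6-fold higher number from compound 3 to compound 4 (0.20 log units; within the scatter), so the two compounds cannot be told apart in this test. On this nitrogen, then, a 2,4,6-trimethylphenyl ring with no oxygen gives a reading that matches that of the oxygen-bearing 4-methoxybenzyl group, so this large change of group leaves no effect that can be distinguished from scatter. Compound 4 also gives a second true number in a set where limits remain common: the limit of > 100000 nM in this assay, at which 2 of the 4 values shown sit.

From the compounds shown here alone, whether the nitrogen would respond differently to a plain phenyl ring, with no methyl groups, remains open. So does the effect of a carboxylic acid or a longer chain ending in an amine at the same place.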